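Methoxy for Methyl on the Shared Core

A few compounds are considered here, and "the series" means these few. Any claim that something is new, unique, unknown or untested is made for them only; others in the source may bear on it.

Of the compounds shown here, two with the same core have been tested in a physicochemical assay for solubility; a higher number here means a more soluble compound, a lower number a less soluble compound. Compound 1 `C[C@H](Oc1ccc(S(C)(=O)=O)cc1C(=O)N1Cc2ccccc2C1)C(F)(F)F` gives < 1 ug/mL, which is a limit of the assay and not a number. Within the data shown here, compound 2 `Cc1cccc2c1CN(C(=O)c1cc(S(C)(=O)=O)ccc1O[C@@H](C)C(F)(F)F)C2` gives 73 ug/mL, the only true number so far. The next candidate is compound 3 `COc1cccc2c1CN(C(=O)c1cc(S(C)(=O)=O)ccc1O[C@@H](C)C(F)(F)F)C2`, which carries a change at the methyl group of compound 2: methoxy in place of methyl on an aromatic carbon. In words, methoxy stands in place of methyl on an aromatic carbon.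

Among the measured compounds shown here, no measured step makes this exchange. For the measured compounds named here, the one step available put methyl in place of hydrogen on an aromatic carbon, and an at least 73-fold higher number from compound 1 to compound 2 (1.86 log units; beyond the scatter) is large and beyond the scatter. On these data alone, that step rests on (the limit of < 1 ug/mL in this assay, at which 1 of the 2 values shown sits), so its full size remains unknown, and it offers only a loose guide to a swap of methyl for methoxy. The expectation therefore stays anchored on compound 2 at 73 ug/mL, with no large move in either direction and a slight lean downward. The estimated change is a 1.5-fold lower number from compound 2 to compound 3 (0.16 log units; within the scatter). For compound 3 the expected value is 50 ug/mL, with an estimated range of 12 ug/mL to 200 ug/mL.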

Compound 3, solubility: 85 ug/mL
Estimate against measurement, compound 3: 1.7-fold (0.23 log units) below, within the range that was stated.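

In this assay, the exchange at this aromatic carbon, ortho to a fused ring and meta to a fused ring, gives a 1.2-fold higher number from compound 2 to compound 3 (0.07 log units; within the scatter), so methyl and methoxy cannot be told apart at this position in this read-out. The earlier compounds shown here showed only what methyl did in place of hydrogen, and methoxy in place of hydrogen now gives an at least 85-fold higher number from compound 1 to compound 3 (1.92 log units; beyond the scatter), so the large step is no longer tied to methyl alone and holds for two different groups at this carbon. Compound 1 carries a limit and not a number, and the full size of the step from it to either compound stays unknown, which also means the two steps from hydrogen cannot be ranked against each other: the limit of < 1 ug/mL in this assay, at which 1 of the 3 values shown sits.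

On these data alone, whether the step holds for a quite different group at this carbon, such as an amine, a carboxylic acid or a longer chain, stays open. The compounds shown also cover only this one place on the shared core, and they offer no measurement that would explain why either group goes with the step from hydrogen.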